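A few compounds are considered here, and "the series" means these few. Any claim that something is new, unique, unknown or untested is made for them only; others in the source may bear on it.

Compound 3 `CCCCCC(=O)c1ccn(-c2ccc3c(c2)B(O)OC3)c1` carries a pentyl group on its carbonyl carbon. In an ADME assay on L929 cells (Mus musculus) for cytotoxicity, read by resazurin assay, with a stated time of 72 h (on this read-out lower numbers stand for stronger inhibition and higher numbers for weaker inhibition), compound 3 gives > 10 ug/mL, which is a limit of the assay rather than a number. Compound 1 `O=C(c1ccc(F)cc1)c1ccn(-c2ccc3c(c2)B(O)OC3)c1` in this assay gives > 10 ug/mL, also a limit. Compound 2 `O=C(CCc1ccccc1)c1ccn(-c2ccc3c(c2)B(O)OC3)c1` in this assay gives > 10 ug/mL, again a limit. So (the limit of > 10 ug/mL in this assay, at which 3 of the 3 values shown sit), and the steps a step that the two limits leave unreadable from compound 1 to compound 2, a step that the two limits leave unreadable from compound 1 to compound 3 and a step that the two limits leave unreadable from compound 2 to compound 3 cannot be sized. Compound 4 `O=C(c1ccn(-c2ccc3c(c2)B(O)OC3)c1)C1CCCCC1` differs from compound 3 by cyclohexyl in place of pentyl on a carbonyl carbon. For the measured compounds named here, no measured step bears on this change, so no shift beyond the scatter is expected from compound 3 to compound 4, a step estimated at a step that the limit leaves unreadable from compound 3 to compound 4. In this assay compound 4 is expected to give about 15 ug/mL, in the range 7 ug/mL to 40 ug/mL.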

Compound 4, half-maximal inhibitory concentration: > 10 ug/mL
Compound 4: a limit, no number (the forecaster's own chance of this, stated with the estimate: 80%); the middle value lies beyond the limit too.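

For the compounds shown here, no step from compound 1, compound 2 or compound 3 to compound 4 can be read, because all four values are limits: the limit of > 10 ug/mL in this assay, at which 4 of the 4 values shown sit. Still open, as far as these compounds go, is how far each compound lies beyond that limit in this assay, and whether the group on the carbonyl carbon changes the read-out at all.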